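A few compounds are considered here, and "the series" means these few. Any claim that something is new, unique, unknown or untested is made for them only; others in the source may bear on it.

Working notes on the series.

In a functional assay on PC-3 cells (Homo sapiens) for cytotoxicity, read by MTT assay, with a stated time of 48 h (on this read-out higher numbers stand for weaker inhibition and lower numbers for stronger inhibition), three compounds carrying the shared core have been measured. Compound 1 `CC1=NN(C(=O)CN2CCC(c3ccccc3)CC2)C(c2ccccc2O)C1` gives 20400 nM. Compound 2 `O=C(CCl)N1N=C(c2cc3ccccc3oc2=O)CC1c1ccccc1` gives 2980 nM. Compound 3 `CC(C)(C)NCC(=O)N1N=C(c2cc3ccccc3oc2=O)CC1c1ccccc1` gives 16400 nM, which places compound 3 second highest of the three numbers, within the scatter of compound 1 and well apart from compound 2. Among the compounds with values here, the one single-point step measured so far, a 5.5-fold higher number from compound 2 to compound 3 (0.74 log units; beyond the scatter), shows that exchanging the chloro for (tert-butyl)amino at this position carries a modest but clear cost.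

Compound 4 `CN1CCN(CC(=O)N2N=C(c3cc4ccccc4oc3=O)CC2c2ccccc2)CC1` continues along the same chain carbon: 4-methylpiperazin-1-yl in place of (tert-butyl)amino on a saturated chain carbon bound to a carbonyl carbon. Both compound 3 and compound 4 carry a basic amine at this position, so the change does not revisit the chloro of compound 2; the step of a 5.5-fold higher number from compound 2 to compound 3 (0.74 log units; beyond the scatter) speaks only to amine-versus-chloro and is not a guide to one amine against another. Within the data shown here, no measured pair tells how the 4-methylpiperazin-1-yl compares with (tert-butyl)amino on this core. The working expectation is therefore a step of no clear size, and compound 4 is expected to sit near compound 3, with a 1.1-fold lower number from compound 3 to compound 4 (0.04 log units; within the scatter) estimated as within the scatter. Compound 4 is estimated at 15000 nM, with a range from 5000 nM to 45000 nM in this assay.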

Compound 4, half-maximal inhibitory concentration: 25800 nM
Compound 4: middle estimate off by 1.7-fold (0.24 log units), on the low side; the measured number falls inside the stated range.
By their numbers in this assay, from the lowest: compound 2; then compounds 3, 1 and 4 (each within the scatter of the next).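

Within the data shown here, the step of a 1.6-fold higher number from compound 3 to compound 4 (0.20 log units; within the scatter) is the first comparison of one amine with another on a saturated chain carbon bound to a carbonyl carbon, and in this assay it does not separate 4-methylpiperazin-1-yl from (tert-butyl)amino, even though the entering group brings a six-membered non-aromatic ring with 2 hetero atoms and 0 hydrogen-bond donors. The step of an 8.7-fold higher number from compound 2 to compound 4 (0.94 log units; beyond the scatter) shows that the higher number relative to the chloro of compound 2 is not confined to (tert-butyl)amino, as the two amines shown both stand apart from chloro at this position while staying within the scatter of each other. No measurement at hand bears on what lies behind these steps.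

Still open, going by these compounds, is whether a morpholin-4-yl or a piperidin-1-yl on this chain carbon would stay with compound 3 and compound 4, and whether a bromo would stay with compound 2. Also open, on these data alone, is how a longer chain carrying the 4-methylpiperazin-1-yl would read on the shared core, and whether a carboxylic acid in its place would fall with the amines or with the chloro.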